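Cyclopentyl for tert-butyl on the furan of compound 2

This account rests on a few compounds, and the source may have more. Where it says the series, first, only, none or still open, it means among the compounds named here.

Compound 1 `CC[C@@H](Nc1c(Nc2cccc(C(=O)N(C)C)c2O)c(=O)c1=O)c1sccc1C` — 123 nM
Compound 2 `CC[C@@H](Nc1c(Nc2cccc(C(=O)N(C)C)c2O)c(=O)c1=O)c1cc(C(C)(C)C)co1` — 10 nM

Among the compounds with values here, in an assay on CHO cells for displacement of a labelled ligand from C-X-C chemokine receptor type 1 (Homo sapiens) (on this read-out higher numbers stand for weaker inhibition and lower numbers for stronger inhibition), compound 2 gives 10 nM, the lowest of the two numbers so far; its only neighbour is compound 1, which gives 123 nM, and the single measured step between them runs a 12-fold lower number from compound 1 to compound 2 (1.09 log units; beyond the scatter). Compound 3 `CC[C@@H](Nc1c(Nc2cccc(C(=O)N(C)C)c2O)c(=O)c1=O)c1cc(C2CCCC2)co1` differs from compound 2 by cyclopentyl in place of tert-butyl on an aromatic carbon. Within the data shown here, no measured step bears on this exchange: the one step known, a 12-fold lower number from compound 1 to compound 2 (1.09 log units; beyond the scatter), concerns the five-membered aromatic ring itself and not the group carried on it, so the data hold no guide to the size or direction of the change. With nothing in the numbers to weigh for or against it, the step is expected to run a 1.2-fold higher number from compound 2 to compound 3 (0.08 log units; within the scatter), none beyond the scatter. Compound 3 is therefore estimated at 12 nM, within a range of 4 nM to 40 nM.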

Compound 3, inhibition constant: 53 nM
The estimate for compound 3 lay 4.4-fold (0.65 log units) below the measured number; the whole stated range lies below it.
By their numbers in this assay, from the lowest: compound 2; then compound 3; then compound 1.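

In this assay, the carbon two ring bonds from the ring oxygen of the furan does not treat its two carbon groups alike: cyclopentyl in place of tert-butyl gives a 5.3-fold higher number from compound 2 to compound 3 (0.72 log units; beyond the scatter) and so costs much of what compound 2 had gained. The 4-cyclopentylfuran-2-yl group still beats 3-methylthiophen-2-yl, with a 2.3-fold lower number from compound 1 to compound 3 (0.37 log units; beyond the scatter) as against a 12-fold lower number from compound 1 to compound 2 (1.09 log units; beyond the scatter) for the 4-(tert-butyl)furan-2-yl group, so the advantage over compound 1 survives this exchange but shrinks. Nothing available offers a reason for the difference between the two groups.

From the compounds shown here alone, it remains open whether other carbon groups at this position, such as isopropyl, cyclobutyl or cyclohexyl, would stay closer to tert-butyl or to cyclopentyl. Going by these compounds, how a hydroxyl or an amine would fare on the same ring carbon also remains open.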